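Ester variation on the shared core: benzyl ester

A few compounds are considered here, and "the series" means these few. Any claim that something is new, unique, unknown or untested is made for them only; others in the source may bear on it.

Compound 1 `CCCOC(=O)C1=C(C)NC(C)=C(C(=O)OC)C1c1csc(-c2ccc(Cl)cc2)n1` gives 5920 nM in an assay on isolated protein for antagonist activity at Voltage-dependent L-type calcium channel subunit alpha-1C (Cavia porcellus), with a stated time of 15 min; on this read-out higher numbers stand for weaker inhibition and lower numbers for stronger inhibition. Compound 2 `COC(=O)C1=C(C)NC(C)=C(C(=O)OC2CCCC2)C1c1csc(-c2ccc(Cl)cc2)n1` gives 7290 nM in this assay, the higher of the two numbers, though its gap to compound 1 lies within the scatter. Among the measured compounds shown here, the one step measured so far, a 1.2-fold higher number from compound 1 to compound 2 (0.09 log units; within the scatter), also exchanged the group on this oxygen and stayed within the scatter. Compound 3 `COC(=O)C1=C(C)NC(C)=C(C(=O)OCc2ccccc2)C1c1csc(-c2ccc(Cl)cc2)n1` carries benzyl in place of cyclopentyl on an oxygen next to a carbonyl group. For the measured compounds named here, only that single step bears on this change, and it produced nothing beyond the scatter, so the two numbers measured give no ground to expect a shift in either direction. The expected step in this assay is a 1.0-fold lower number from compound 2 to compound 3 (0.02 log units; within the scatter), within the scatter. Compound 3 is therefore estimated at 7000 nM in this assay, with an expected range from 2500 nM to 20000 nM.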

Compound 3, half-maximal inhibitory concentration: 64900 nM
For compound 3 the middle estimate is 9.3-fold (0.97 log units) below the measured one; measured number outside the range, above it.
By their numbers in this assay, from the lowest: compounds 1 and 2 (each within the scatter of the next); then compound 3.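

In this assay, the group on this oxygen next to a carbonyl group does matter: benzyl in place of cyclopentyl gives an 8.9-fold higher number from compound 2 to compound 3 (0.95 log units; beyond the scatter), and the same comparison against the propyl ester, read as phenyl in place of ethyl on a saturated chain carbon bound to an oxygen next to a carbonyl group, gives an 11-fold higher number from compound 1 to compound 3 (1.04 log units; beyond the scatter). Propyl and cyclopentyl could not be told apart, so among these three esters only benzyl separates, towards weaker inhibition. Nothing available accounts for this loss.

Benzyl differs from cyclopentyl in both its aromatic ring and its heavy-atom count, and these compounds do not separate the two. A cyclohexyl ester and a phenylethyl ester on the same oxygen would bear on that question.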